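Adding a Methoxy to Compound 1: Expected Antiproliferative Effect

The compounds below may be only part of what the source reports. "The series", "measured", "known", "first", "only" and "open" are said of these compounds alone.

Measured compounds:
compound 1, `COc1ccc(C(=O)/C=C/c2cc(-c3cc(OC)c(OC)c(OC)c3)n3nc(-c4ccccc4)cc3n2)cc1OC`, 29900 nM
compound 2, `COc1ccc(C(=O)/C=C/c2cc(-c3ccc(OC)c(OC)c3)n3nc(-c4ccccc4)cc3n2)cc1OC`, 7200 nM
compound 3, `COc1ccc(-c2cc(/C=C/C(=O)c3ccc(OC)c(OC)c3)nc3cc(-c4ccccc4)nn23)cc1`, 16400 nM

In a functional assay on DU-145 cells (Homo sapiens) for antiproliferative activity, read by MTT assay, with a stated time of 24 h (on this read-out higher numbers stand for weaker inhibition and lower numbers for stronger inhibition), compound 1 gives the highest of the three numbers; compound 3 lies nearest to it, and compound 2 furthest, as the steps of a 1.8-fold lower number from compound 1 to compound 3 (0.26 log units; within the scatter) and a 4.2-fold lower number from compound 1 to compound 2 (0.62 log units; beyond the scatter) show. Compound 4, `COc1cc(C(=O)/C=C/c2cc(-c3cc(OC)c(OC)c(OC)c3)n3nc(-c4ccccc4)cc3n2)cc(OC)c1OC`, differs from compound 1 by methoxy in place of hydrogen on an aromatic carbon. For the measured compounds named here, no measured step changes the same ring in the same way. The two steps that add or remove a methoxy on an aromatic carbon, a 4.2-fold lower number from compound 1 to compound 2 (0.62 log units; beyond the scatter) and a 2.3-fold higher number from compound 2 to compound 3 (0.36 log units; beyond the scatter), concern the aryl group on the shared core and point in opposite directions, so they give no consistent guide for the ring altered here. Compound 4 is therefore expected to show a step of about a 1.2-fold lower number from compound 1 to compound 4 (0.08 log units; within the scatter), which means no change beyond the scatter; the estimate for compound 4 in this assay is 25000 nM, with a range from 8000 nM to 80000 nM.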

Compound 4, half-maximal inhibitory concentration: 34900 nM
Beside the measured number, compound 4's estimate is 1.4-fold (0.14 log units) below it, within the range that was stated.
By their numbers in this assay, from the lowest: compound 2; then compounds 3, 1 and 4 (each within the scatter of the next, the first and the last beyond it).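

For the compounds shown here, replacing the 3,4-dimethoxyphenyl of compound 1 with 3,4,5-trimethoxyphenyl gives the first reading for this ring in this assay: a 1.2-fold higher number from compound 1 to compound 4 (0.07 log units; within the scatter). Methoxy in place of hydrogen here, ortho to a methoxy group, therefore brings no change beyond the scatter, whereas the change on the other aryl group, a 4.2-fold lower number from compound 1 to compound 2 (0.62 log units; beyond the scatter), goes beyond it. The size of the change also cannot be told apart between the two cores on which it can be compared: the same change on two cores in this assay, a 2.3-fold higher number (0.36 log units; beyond the scatter) from compound 2 to compound 3 and a 1.2-fold lower number (0.07 log units; within the scatter) from compound 4 to compound 1, 2.7-fold (0.42 log units) apart, within the scatter of two such steps.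

The compounds shown leave open whether a different group on this ring, such as a hydroxyl, an amine or a longer alkoxy chain, would shift the number. They also leave open whether taking a methoxy away from this ring would do so, and whether the flat result holds on other cells.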